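Hydroxy in place of methyl at the quaternary ring carbon

The source may report more compounds than this note shows. Statements on the series, on what has been measured and on what is new or still open speak of the compounds shown alone.

Measured compounds:
compound 1 `CC(=O)O[C@@H]1OC(=O)[C@](C)(C(C)=O)[C@@H]1C` — 5000 nM
compound 2 `CC(=O)O[C@@H]1OC(=O)[C@@](C(C)=O)(C2SCCCS2)[C@@H]1C` — a limit of the assay, > 50000 nM
compound 3 `CC(=O)O[C@@H]1OC(=O)[C@@](C)(C(C)=O)[C@@H]1C` — 12000 nM

Compound 3 holds the highest of the two numbers in a functional assay on HT-29 cells (Homo sapiens) for cytotoxicity, read by MTT assay; a higher number here means a weaker inhibitor, a lower number a stronger inhibitor. Its nearest neighbour is compound 1, and the step of a 2.4-fold higher number from compound 1 to compound 3 (0.38 log units; beyond the scatter) rests on (the fact that compounds 1 and 3 differ only in the configuration as drawn). For compound 2 only a limit is known, (the limit of > 50000 nM in this assay, at which 1 of the 3 values shown sits). Going by the values given here, the step of an at least 10-fold higher number from compound 1 to compound 2 (1.00 log units; beyond the scatter) is the only one at a saturated ring carbon of this core.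

Compound 4 `CC(=O)O[C@@H]1OC(=O)[C@@](O)(C(C)=O)[C@@H]1C` differs from compound 3 by hydroxy in place of methyl on a saturated ring carbon. Neither measured step exchanges methyl for hydroxy: the step from compound 1 to compound 2 replaces the same kind of carbon with a far larger group, and the step from compound 1 to compound 3 changes configuration only. Among the compounds with values here, a small substituent swap at this carbon therefore has no direct precedent; a modest weakening at most is expected, as a 1.7-fold higher number from compound 3 to compound 4 (0.22 log units; within the scatter). Compound 4 is estimated at 20000 nM, in the range 5000 nM to 80000 nM.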

Compound 4, half-maximal inhibitory concentration: > 50000 nM
Compound 4: only a limit was reported; the forecaster's own chance of this, stated with the estimate: 20%; middle value at least 2.5-fold (0.39 log units) away from the limit.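

In this assay compound 4 gives > 50000 nM, which is a limit of the assay and not a number. The step, an at least 4.1-fold higher number from compound 3 to compound 4 (0.61 log units; beyond the scatter), shows that hydroxy in place of methyl on this saturated ring carbon weakens the compound beyond the scatter, although only one heavy atom is exchanged. Earlier, the only substituent change at this carbon was the much larger six-membered ring group of compound 2, so the position now proves responsive to a small exchange as well, and the top of the measurable range is reached a second time: the limit of > 50000 nM in this assay, at which 2 of the 4 values shown sit.

Going by these compounds, the true size of the loss stays unknown, and so does whether hydroxy has the same result in the configuration of compound 1. Also open, on these data alone, is whether an amine or a methoxy group at this carbon would stay close to compound 3 or fall to the same limit.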